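Replacing Isopropyl on an Oxygen Next to a Carbonyl

The source may report more compounds than this note shows. Statements on the series, on what has been measured and on what is new or still open speak of the compounds shown alone.

Compound 1 `CC(C)OC(=O)c1cccc(NC(=O)[C@@H]2C[C@H](SC3=C(C(=O)O)N4C(=O)[C@H]([C@@H](C)O)[C@H]4[C@H]3C)CN2)c1` gives > 95% in an ADME assay for metabolic stability, read by LC-MS, with a stated time of 3 h, at pH 6.5, tested at 50 uM (a higher number here means that more of the compound is left, a lower number that less of the compound is left), which is a limit of the assay and not a number.
Compound 2 `CC(C)OC(=O)C1=C(S[C@@H]2CN[C@H](C(=O)Nc3cccc(C(=O)OC(C)C)c3)C2)[C@H](C)[C@@H]2[C@@H]([C@@H](C)O)C(=O)N12` gives > 95% in this assay, again a limit.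
Compound 3 `C[C@@H](O)[C@H]1C(=O)N2C3=C(S[C@@H]4CN[C@@H](C4)C(=O)Nc4cccc(c4)C(=O)OCCCOC3=O)[C@H](C)[C@H]12` gives > 95% in this assay, again a limit.

Compound 1 therefore stands at the limit (the limit of > 95% in this assay, at which 3 of the 3 values shown sit), and the numbers shown do not place it relative to compound 2 or compound 3. Among the measured compounds shown here, the only step between measured compounds, a step that the two limits leave unreadable from compound 1 to compound 2, has a limit at both ends, so its size cannot be read. Compound 4 `C[C@@H](O)[C@H]1C(=O)N2C(C(=O)O)=C(S[C@@H]3CN[C@H](C(=O)Nc4cccc(C(=O)OCOC(=O)C(C)(C)C)c4)C3)[C@H](C)[C@H]12` differs from compound 1 by (((tert-butyl)carbonyl)oxy)methyl in place of isopropyl on an oxygen next to a carbonyl group. For the measured compounds named here, no measured step bears on this change with a readable size, so the expectation for compound 4 rests only on where compound 1 stands, with a range widened to allow for a change of this size. Compound 4 is estimated at 90% in this assay, between 65% and 100%, which means an expected step of a number at least 5 percentage points lower from compound 1 to compound 4 (that floor lies within the scatter).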

Compound 4, percent of the compound remaining: > 95%
Compound 4 was reported as a limit; the forecaster's own chance of this, stated with the estimate: 55%; middle value at least 5 percentage points away from the limit.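

Compound 1 and compound 4 both stand at a limit of the assay, so the step between them cannot be read. The compounds shown leave open whether any of them differs from another in this assay, since all stand at one limit: the limit of > 95% in this assay, at which 4 of the 4 values shown sit.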